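Methoxy addition to the anilide of compound 3

This account rests on a few compounds, and the source may have more. Where it says the series, first, only, none or still open, it means among the compounds named here.

Measured so far, in a functional assay on SK-BR-3 cells (Homo sapiens) for antiproliferative activity, read by MTT assay, with a stated time of 48 h; a lower number here means a stronger inhibitor, a higher number a weaker inhibitor:
compound 1 `CCCCCCOc1cc(NC(=O)c2ccc(OC)cc2)ccc1N(C)S(C)(=O)=O` gives 20000 nM
compound 2 `CCCCCCOc1cc(NC(=O)c2ccc(OC)c(OC)c2)ccc1N(C)S(C)(=O)=O` gives 100000 nM
compound 3 `COc1ccc(C(=O)Nc2ccc(NS(C)(=O)=O)c(OCc3cc(OC)ccc3OC)c2)cc1` gives 13.4 nM

Compound 4 `COc1ccc(OC)c(COc2cc(NC(=O)c3ccc(OC)c(OC)c3)ccc2NS(C)(=O)=O)c1` has not been measured.

On the core of compound 1 a single change has been tested: methoxy in place of hydrogen on an aromatic carbon. Its step is a 5.0-fold higher number from compound 1 to compound 2 (0.70 log units; beyond the scatter), a modest loss. Compound 3 stands far apart from that pair: its number in this assay is the lowest of the three, well beyond the scatter from compound 1 and further still from compound 2. The difference between the core of compound 3 and the core of compound 1 is not broken down here.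

Compound 4 carries the same change onto the core of compound 3: methoxy in place of hydrogen on an aromatic carbon. Among the compounds with values here, the surroundings of the place are described in the same words for both pairs, so this is the same change, now made in a core for which no other step is known. Within the data shown here, the one guide is the pair compound 1 and compound 2, whose step a 5.0-fold higher number from compound 1 to compound 2 (0.70 log units; beyond the scatter) was measured in weakly active compounds; whether a core as potent as that of compound 3 answers alike is untested, so the range is kept wide. Compound 4 is expected to show a 3.7-fold higher number from compound 3 to compound 4 (0.57 log units; beyond the scatter), about the size of the earlier step. Compound 4 is thus estimated at 50 nM in this assay, between 15 nM and 200 nM.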

Compound 4, half-maximal inhibitory concentration: 11 nM
Compound 4: middle estimate off by 4.5-fold (0.66 log units), on the high side; the whole stated range lies above it.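

In this assay, going from 4-methoxyphenyl to 3,4-dimethoxyphenyl on the core of compound 3 gives a 1.2-fold lower number from compound 3 to compound 4 (0.09 log units; within the scatter), so the added methoxy leaves no measurable change on this core. The change therefore does not carry over at a single size between the two cores, and the loss seen on the core of compound 1 does not reappear on the core of compound 3: the same change on two cores in this assay, a 5.0-fold higher number (0.70 log units; beyond the scatter) from compound 1 to compound 2 and a 1.2-fold lower number (0.09 log units; within the scatter) from compound 3 to compound 4, 6.1-fold (0.78 log units) apart, beyond the scatter of two such steps

Within the data shown here, this rests on only two pairs, in one cell line, and it shows that the core can alter the outcome of the change; it does not show which feature of the core does so, nor how the change would behave on any third core.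

The compounds shown leave open which of the differences between the core of compound 1 and the core of compound 3 governs the size of the step, and whether a hydroxy, an ethoxy or a fluorine in the place of the added methoxy would read the same on the core of compound 3. Also open, going by these compounds, is whether the result on the core of compound 3 holds in other cell lines or at another exposure time.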